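The source may hold more compounds than are shown below. What is called first, only, known or untested is meant among the compounds shown, and "the series" means these compounds.

Compound 1 `Cc1c(Cl)c(=O)oc2cc(OCCCCSC(=S)N3C(C)CCCC3C)ccc12` and compound 2 `Cc1c(Cl)c(=O)oc2cc(OCCCSC(=S)N3C(C)CCCC3C)ccc12` share one core and differ only in the length of the chain that joins it to the dithiocarbamate. In an assay on isolated protein for inhibition of Amine oxidase [flavin-containing] B (Homo sapiens), read by Amplex Red, with stated times of 15 min and 20 min (on this read-out higher numbers stand for weaker inhibition and lower numbers for stronger inhibition), compound 1 gives 101 nM, and compound 2 gives 101 nM; the two values lie within the usual scatter of each other, so compound 1 stands level with compound 2. Compound 3 `Cc1c(Cl)c(=O)oc2cc(OCCCCSC(=S)N3CCCCC3C)ccc12` is compound 1 with hydrogen in place of methyl on a saturated ring carbon. Going by the values given here, no measured pair shows what losing this methyl does, so a small step, or none beyond the scatter, is expected. Compound 3 is expected to give 130 nM in this assay, between 50 nM and 350 nM, a step of a 1.3-fold higher number from compound 1 to compound 3 (0.11 log units; within the scatter).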

Compound 3, half-maximal inhibitory concentration: 8.9 nM
The estimate for compound 3 lay 15-fold (1.16 log units) above the measured number; the whole stated range lies above it.
By their numbers in this assay, from the lowest: compound 3; then compounds 1 and 2 (each within the scatter of the next).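

Taking one methyl off the ring, so that 2,6-dimethylpiperidin-1-yl becomes 2-methylpiperidin-1-yl, gives an 11-fold lower number from compound 1 to compound 3 (1.05 log units; beyond the scatter) in this assay. This position therefore has a strong bearing on inhibition, which the earlier pair could not show, since those two compounds differ only in chain length and stand level. Nothing measured here explains the size of this step.

As far as these compounds go, it remains open whether removing the second methyl to leave a plain piperidin-1-yl group, or replacing it with ethyl, would lower the number further. From the compounds shown here alone, whether the same step holds on the shorter chain of compound 2 is also open.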